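Benzylsulfanyl variation in a sulfonylguanidine hydrazone series

The compounds below may be only part of what the source reports. "The series", "measured", "known", "first", "only" and "open" are said of these compounds alone.

Measured so far:
compound 1 `C/C(C#Cc1ccccc1)=N\N/C(N)=N/S(=O)(=O)c1cc(C)c(Cl)cc1SCc1ccccc1Cl` with 25000 nM
compound 2 `C/C(C#Cc1ccccc1)=N\N/C(N)=N/S(=O)(=O)c1cc(C)c(Cl)cc1SCc1ccc(Cl)cc1` with 8000 nM

Among the compounds with values here, in a functional assay on HeLa cells (Homo sapiens) for antiproliferative activity, read by MTT assay, with a stated time of 72 h (a higher number here means a weaker inhibitor, a lower number a stronger inhibitor), compound 2 gives 8000 nM, the lowest of the two numbers; the only other value is that of compound 1 at 25000 nM. Within the data shown here, the single measured step, a 3.1-fold lower number from compound 1 to compound 2 (0.49 log units; beyond the scatter), moves a chlorine around the ring. Compound 3 `C/C(C#Cc1ccccc1)=N\N/C(N)=N/S(=O)(=O)c1cc(C)c(Cl)cc1SCc1cccc2ccccc12` instead carries naphthalen-1-yl in place of 4-chlorophenyl on a saturated chain carbon bound to a sulfur. Among the measured compounds shown here, no measured step bears directly on this exchange, so the expected step of a 1.3-fold lower number from compound 2 to compound 3 (0.12 log units; within the scatter) is small, near or within the scatter, with a wide range. Compound 3 is estimated at 6000 nM (range 2000 nM to 20000 nM).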

Compound 3, half-maximal inhibitory concentration: 125000 nM
Estimate against measurement, compound 3: 21-fold (1.32 log units) below, outside the stated range (above it).
By their numbers in this assay, from the lowest: compound 2; then compound 1; then compound 3.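

In this assay the position on a saturated chain carbon bound to a sulfur responds far more strongly than the move of the chlorine suggested: naphthalen-1-yl in place of 4-chlorophenyl gives a 16-fold higher number from compound 2 to compound 3 (1.19 log units; beyond the scatter) as a large loss. Against 2-chlorophenyl the same group still gives a 5.0-fold higher number from compound 1 to compound 3 (0.70 log units; beyond the scatter), which makes compound 3 the weakest of the three. Nothing at hand explains this loss.

The compounds shown leave open how naphthalen-2-yl or an unsubstituted phenyl would read here, and so whether the loss follows the second ring or its point of attachment.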